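The source may hold more compounds than are shown below. What is called first, only, known or untested is meant among the compounds shown, and "the series" means these compounds.

Compound 1 `CS(=O)(=O)c1cccc2c1[n+]([O-])nc(N)[n+]2[O-]` and compound 2 `CS(=O)(=O)c1ccc2c(c1)[n+]([O-])nc(N)[n+]2[O-]` are built from the same atoms joined differently; the difference between their two cores is not broken down here. In a physicochemical assay on HT-29 cells for lipophilicity (a lower number here means a more polar compound, a higher number a more lipophilic compound), compound 1 gives -1.38, and compound 2 gives -1.15, the two lying within the usual scatter of this measurement. Compound 3 `Nc1n[n+]([O-])c2c(Cl)cccc2[n+]1[O-]` carries chloro in place of methylsulfonyl on an aromatic carbon, and in this assay compound 3 gives 0.166, so that a number 1.55 log units higher from compound 1 to compound 3 (beyond the scatter). Compound 4 `Nc1n[n+]([O-])c2cc(Cl)ccc2[n+]1[O-]` has not yet been measured; it carries chloro in place of methylsulfonyl on an aromatic carbon. Within the data shown here, this is the same kind of change as the one from compound 1 to compound 3, but not the same, since here the group sits meta to a fused ring and para to a fused ring rather than ortho to a fused ring and meta to a fused ring. Because a number 1.55 log units higher from compound 1 to compound 3 (beyond the scatter), a step of similar size is expected for compound 4, namely a number 1.50 log units higher from compound 2 to compound 4 (beyond the scatter). In this assay compound 4 is therefore expected to give 0.35.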

Compound 4, partition coefficient: 0.441
For compound 4 the middle estimate is 0.09 log units below the measured one; measured number inside the range.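

In this assay the swap of methylsulfonyl for chloro gives a number 1.59 log units higher from compound 2 to compound 4 (beyond the scatter) and, on the other core, a number 1.55 log units higher from compound 1 to compound 3 (beyond the scatter) so the change goes the same way and is large in both pairs. This shows that the step carried over between these two cores, with the group in two different places, but two pairs cannot show that it would hold on any other core or at any other place. Nothing given here says why the step has this size.

Groups such as an amine, a carboxylic acid or a longer chain are not among the compounds shown. From the compounds shown here alone, how they would compare with chloro and methylsulfonyl on these cores remains open.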